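Capping the pyrrolidine nitrogen on the shared core

A few compounds are considered here, and "the series" means these few. Any claim that something is new, unique, unknown or untested is made for them only; others in the source may bear on it.

Measured in a functional assay on HCC827 cells (Homo sapiens) for antiproliferative activity, read by MTT assay, with a stated time of 72 h; a lower number here means a stronger inhibitor, a higher number a weaker inhibitor:
- compound 1 `CC(=O)Nc1cccc(-n2c(Nc3ccc(F)cc3)nc3cnc(Nc4ccc(N5CCN(C)CC5)cc4)nc32)c1`: 10 nM
- compound 2 `CN1CCN(c2ccc(Nc3ncc4nc(Nc5ccc(F)cc5)n([C@@H]5CCNC5)c4n3)cc2)CC1`: 300 nM

For the measured compounds named here, compound 2 stands at the highest number of the two, and its only neighbour is compound 1, reached through a 30-fold higher number from compound 1 to compound 2 (1.48 log units; beyond the scatter). That single measured step exchanges the whole substituent on the aromatic nitrogen and is large; it says nothing direct about what happens when the pyrrolidine nitrogen of compound 2 is substituted rather than left bare.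

Compound 3 `CCOC(=O)CN1CC[C@H](n2c(Nc3ccc(F)cc3)nc3cnc(Nc4ccc(N5CCN(C)CC5)cc4)nc32)C1` differs from compound 2 only by 1-((ethoxycarbonyl)methyl)pyrrolidin-3-yl in place of pyrrolidin-3-yl on an aromatic nitrogen. Going by the values given here, no measured pair bears on this kind of change, so the expectation rests on the core being kept intact and on compound 2 as the anchor at 300 nM. The change is expected to give a 1.5-fold lower number from compound 2 to compound 3 (0.18 log units; within the scatter), not beyond the scatter. For compound 3 in this assay the estimate is 200 nM, with a range from 60 nM to 700 nM.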

Compound 3, half-maximal inhibitory concentration: 1810 nM
For compound 3 the middle estimate is 9.1-fold (0.96 log units) below the measured one; measured number outside the range, above it.
By their numbers in this assay, from the lowest: compound 1; then compound 2; then compound 3.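

In this assay, the 1-((ethoxycarbonyl)methyl)pyrrolidin-3-yl group in place of pyrrolidin-3-yl gives a 6.0-fold higher number from compound 2 to compound 3 (0.78 log units; beyond the scatter), so the pyrrolidine nitrogen does not tolerate this substitution without a shift in the number. The exchange of 3-acetamidophenyl for this capped ring now amounts to a 180-fold higher number from compound 1 to compound 3 (2.26 log units; beyond the scatter), a wider gap than the bare ring showed, and compound 1 stays lowest of the three. No measurement shown here accounts for the rise with this ester-bearing chain.

As far as these compounds go, whether the ester or the added chain as a whole drives the rise stays open: a plain methyl on the pyrrolidine nitrogen, or a carboxylic acid in place of the ethyl ester, would separate the two. From the compounds shown here alone, the opposite configuration at the pyrrolidine stereocentre also remains open.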